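The compounds below may be only part of what the source reports. "The series", "measured", "known", "first", "only" and "open" are said of these compounds alone.

Measured so far in a functional assay, tested at 100 ug/mL; a higher number here means a weaker effect of the compound at the concentration tested, a lower number a stronger effect:
compound 1, `COC(=O)C1=C(C)N(c2ccccc2)C=CC1c1ccccc1`, -25.9%
compound 2, `COC(=O)C1=C(C)N(c2ccc(OC)cc2)C=C(C)C1c1ccccc1`, -19.8%
compound 3, `COC(=O)C1=C(C)N(c2ccccc2)C=C(C)C1c1ccccc1`, -21.1%

All three numbers lie close together in this assay. The step of a number 4.8 percentage points higher from compound 1 to compound 3 (within the scatter) is within the scatter, and so is the step of a number 1.3 percentage points higher from compound 3 to compound 2 (within the scatter). Compound 1 stands at the lowest of the three numbers, but its distance to compound 3 and to compound 2 is within the scatter in both cases, so no order among them is claimed.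

Compound 4, `COC(=O)C1=C(C)N(c2ccccc2)C=CC1c1ccc(OC)cc1`, has not yet been measured in this assay. It differs from compound 1 by methoxy in place of hydrogen on an aromatic carbon. The same change occurs once more among these compounds, between two measured ones: compound 2 differs from compound 3 by methoxy in place of hydrogen on an aromatic carbon, and that step gave a number 1.3 percentage points higher from compound 3 to compound 2 (within the scatter). The two cores differ by hydrogen in place of methyl on a double-bonded ring carbon, which is the step from compound 1 to compound 3 noted above.

On that single precedent, the step from compound 1 to compound 4 is expected to be small, a number 1.3 percentage points higher from compound 1 to compound 4 (within the scatter), because the matching step a number 1.3 percentage points higher from compound 3 to compound 2 (within the scatter) stayed within the scatter. Compound 4 is accordingly estimated at -24.6%, with a likely range from -35% to -14%.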

Compound 4, a percentage reported as activity, at one concentration (the size of the read-out at that concentration, not a potency): -29.8%
For compound 4 the middle estimate is 5.2 percentage points above the measured one, and the stated range covers the measured number.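

In this assay, methoxy in place of hydrogen on an aromatic carbon, here phenyl to 4-methoxyphenyl, gives a number 3.9 percentage points lower from compound 1 to compound 4 (within the scatter). Set beside the earlier step, the change shows no difference between the two cores: the same change on two cores in this assay, a number 1.3 percentage points higher (within the scatter) from compound 3 to compound 2 and a number 3.9 percentage points lower (within the scatter) from compound 1 to compound 4, 5.2 percentage points apart, within the scatter of two such steps. This shows that the change stayed small on both cores at the one concentration tested, but it does not show that the two steps are identical, and two pairs say nothing about how the change would behave on any other core in the series.

The compounds shown leave open whether a group other than methoxy on the aromatic ring, such as an amine, a carboxylic acid or chlorine, would move the read-out beyond the scatter. They also leave open whether a longer chain in place of the methyl of the ester would do so.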